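Propyl amide to ethyl urea on a sulfonate ester scaffold

This account rests on a few compounds, and the source may have more. Where it says the series, first, only, none or still open, it means among the compounds named here.

Of the compounds shown here, three sharing one core have been tested in a functional assay on HT-1080 cells (Homo sapiens) for antiproliferative activity, read by sulforhodamine B assay, with a stated time of 48 h; on this read-out lower numbers stand for stronger inhibition and higher numbers for weaker inhibition. Compound 1 `CCC(=O)Nc1cccc(S(=O)(=O)Oc2ccccc2C(C)C)c1` gives 12000 nM, compound 2 `CCC(=O)Nc1ccc(S(=O)(=O)Oc2ccccc2C(C)C)cc1` gives 2100 nM, and compound 3 `CCCC(=O)Nc1ccc(S(=O)(=O)Oc2ccccc2I)cc1` gives 2000 nM. Compound 3 has the lowest number of the three, yet compound 2 sits within the usual scatter of it, while compound 1 lies clearly beyond. Compound 4 `CCNC(=O)Nc1ccc(S(=O)(=O)Oc2ccccc2I)cc1` is not yet measured; it differs from compound 3 by one change: ethylamino in place of propyl on a carbonyl carbon, an ethylamino in place of propyl on a carbonyl carbon. Going by the values given here, no measured pair shows this change, so a step of modest size, toward weaker inhibition, is expected in this assay a 1.8-fold higher number from compound 3 to compound 4 (0.24 log units; within the scatter). Compound 4 is estimated at 3500 nM, within a range from 1200 nM to 10000 nM.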

Compound 4, half-maximal inhibitory concentration: 140 nM
Compound 4: the middle estimate sits 25-fold (1.40 log units) above what was measured; measured number outside the range, below it.
By their numbers in this assay, from the lowest: compound 4; then compounds 3 and 2 (each within the scatter of the next); then compound 1.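

In this assay ethylamino in place of propyl on a carbonyl carbon brings a 14-fold lower number from compound 3 to compound 4 (1.15 log units; beyond the scatter) although both groups hold 3 heavy atoms. This position therefore responds strongly to a swap of equal heavy-atom count, in which a nitrogen and 1 hydrogen-bond donor enter. No supporting data explain the size of this step. Still open, from the compounds shown here alone, is whether methylamino, the longer butylamino or ethoxy on the same carbonyl carbon would match ethylamino, and whether the same change would give a similar step on another member of this series.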